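The source may report more compounds than this note shows. Statements on the series, on what has been measured and on what is new or still open speak of the compounds shown alone.

The measured compounds, with their values in an assay on cells for inhibition of Indoleamine 2,3-dioxygenase 1 (Homo sapiens), read by HPLC, with a stated time of 20 min; on this read-out lower numbers stand for stronger inhibition and higher numbers for weaker inhibition:

Compound 1 `Cn1cncc1-c1cccc(Cl)c1`: 12900 nM
Compound 2 `Cn1cncc1-c1ccccc1O`: 38000 nM
Compound 3 `Cn1cncc1-c1ccccc1N`: 1700000 nM

Compound 3 stands highest of the three numbers in this assay. Going by the values given here, its nearest neighbour is compound 2, and the step of a 45-fold higher number from compound 2 to compound 3 (1.65 log units; beyond the scatter) is the only one-place change measured in this set; it shows that exchanging one small group on this ring of compound 2 moves the number a long way. Compound 1, whose value is the lowest of the three, differs from compound 3 in two places, so its values only show that a chloro-bearing ring without the amino gives a far lower number.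

Compound 4 `Cn1cncc1-c1cc(Cl)ccc1N` is the next step, from compound 3 by chloro in place of hydrogen on an aromatic carbon. No measured step adds a chloro to an otherwise unchanged ring, so the direction rests on compound 1, whose value 12900 nM is the lowest shown, and on the amino being kept. Compound 4 is therefore expected to give a lower number than compound 3, a step of about a 3.4-fold lower number from compound 3 to compound 4 (0.53 log units; beyond the scatter), though a result within the scatter would not surprise. The estimate for compound 4 is 500000 nM, in a range from 120000 nM to 2000000 nM.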

Compound 4, half-maximal inhibitory concentration: 1200000 nM
Compound 4: the middle estimate sits 2.4-fold (0.38 log units) below what was measured; low and high end bracket the measured number.
By their numbers in this assay, from the lowest: compound 1; then compound 2; then compounds 4 and 3 (each within the scatter of the next).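

In this assay, the step of a 1.4-fold lower number from compound 3 to compound 4 (0.15 log units; within the scatter) shows that chloro in place of hydrogen on this aromatic carbon, para to an amino group and meta to a group of 6 heavy atoms, gives no change that can be told from the scatter when the amino group is present. Going by these compounds alone, the step of a 93-fold higher number from compound 1 to compound 4 (1.97 log units; beyond the scatter) adds what the earlier compounds could not show: with the chloro held in place, adding the amino group gives a large step on its own, so the high numbers of this pair go with the amino group and not with the presence or absence of chloro. Nothing among the data given explains either step.

The compounds shown leave open how the core carrying neither chloro nor amino would stand, and so whether chloro has any effect on a ring without the amino group. They also leave open whether a bromo or a methoxy at the chloro position would behave as chloro does here, and whether a methylamino or an acetamido group would give a step as large as the amino group does.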